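A few compounds are considered here, and "the series" means these few. Any claim that something is new, unique, unknown or untested is made for them only; others in the source may bear on it.

Compound 1 `C[C@H](Nc1cc(=O)oc2cc(OCc3ccccc3)ccc12)C(N)=O` is the starting point of this comparison. In an assay for inhibition of Amine oxidase [flavin-containing] B (Rattus norvegicus) (a higher number here means a weaker inhibitor, a lower number a stronger inhibitor), compound 1 gives 680 nM, which is the highest of the two numbers recorded; the nearest is compound 2 `C[C@H](Nc1cc(=O)oc2cc(OCc3cccc(Cl)c3)ccc12)C(N)=O`, which in this assay gives 210 nM. Among the compounds with values here, the only measured step, a 3.2-fold lower number from compound 1 to compound 2 (0.51 log units; beyond the scatter), comes from a chloro in place of hydrogen on an aromatic carbon, a change at a different place from the one considered here.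

Compound 3 `NC(=O)[C@@H]1CCCN1c1cc(=O)oc2cc(OCc3ccccc3)ccc12` differs from compound 1 in another way: 2-carbamoylpyrrolidin-1-yl in place of (1-carbamoylethyl)amino on an aromatic carbon. Within the data shown here, no measured step bears on this change, since the step from compound 1 to compound 2 leaves the amino substituent untouched, and the two measured compounds both carry the (1-carbamoylethyl)amino group. With nothing in the measured pairs to guide the direction, the expectation is that compound 3 stays close to compound 1, with no step beyond the scatter. The expected step is therefore a 1.3-fold higher number from compound 1 to compound 3 (0.12 log units; within the scatter), taken as lying near the scatter. The estimate for compound 3 in this assay is 900 nM, with a range from 250 nM to 3500 nM.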

Compound 3, half-maximal inhibitory concentration: 16100 nM
Beside the measured number, compound 3's estimate is 18-fold (1.25 log units) below it; the measured number lies above the stated range.
By their numbers in this assay, from the lowest: compound 2; then compound 1; then compound 3.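

In this assay, the place opposite the ring oxygen proves sensitive to the change in its substituent: replacing (1-carbamoylethyl)amino with 2-carbamoylpyrrolidin-1-yl gives a 24-fold higher number from compound 1 to compound 3 (1.37 log units; beyond the scatter). Within the data shown here, this large step shows that the amino substituent can shift the number further than the only earlier change, a chloro on the benzyl ring, which gave a 3.2-fold lower number from compound 1 to compound 2 (0.51 log units; beyond the scatter) in the opposite direction. The entering group brings a five-membered non-aromatic ring and one hydrogen-bond donor in place of two, but nothing available on this result explains why the number rises.

The compounds shown leave open which part of the change matters, since the ring, the lost donor and the added carbons all arrive together; an N-methyl version of the open (1-carbamoylethyl)amino group, or a six-membered piperidine ring carrying the same carbamoyl group, would help to separate them. They also leave open whether a carboxylic acid could stand in place of the primary amide, and whether the chloro would lower the number on compound 3 as it does on compound 1.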